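A few compounds are considered here, and "the series" means these few. Any claim that something is new, unique, unknown or untested is made for them only; others in the source may bear on it.

Measured so far in a functional assay on SW1573 cells (Homo sapiens) for inhibition, read by sulforhodamine B assay, with a stated time of 48 h; on this read-out lower numbers stand for stronger inhibition of growth and higher numbers for weaker inhibition of growth:
compound 1, `COC(=O)[C@@]1(C)CCC=C2[C@@H]1CC[C@@H](C)[C@]2(C)Cc1c[nH]c2ccc(Br)cc12` — 12000 nM
compound 2, `COC(=O)[C@@]1(C)CC[C@@H]2C3=C1CC[C@@H](C)[C@]3(C)Cc1c2[nH]c2ccccc12` — 8300 nM

Within the data shown here, only two compounds have numbers in this assay. Compound 2 gives 8300 nM, and compound 1 gives 12000 nM. Compound 2 has the lower of the two numbers, but its gap to compound 1 lies within the scatter, so no order between the two can be read from these values. Compound 3 `COC(=O)[C@@]1(C)CC[C@@H]2C3=C1CC[C@@H](C)[C@]3(C)Cc1c2[nH]c2ccc(OC)cc12` has not yet been measured. It differs from compound 2 in one place: methoxy in place of hydrogen on an aromatic carbon. Among the measured compounds shown here, no step between two measured compounds shows what this kind of change does in this assay, so the expectation rests on compound 2 alone, with its value of 8300 nM as the anchor. The step of a 1.2-fold lower number from compound 2 to compound 3 (0.07 log units; within the scatter) is therefore expected to be small, none beyond the scatter. Compound 3 is estimated to give 7000 nM, in a range from 2500 nM to 20000 nM.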

Compound 3, concentration for 50% growth inhibition: 5900 nM
Compound 3: the middle estimate sits 1.2-fold (0.07 log units) above what was measured; the measured number falls inside the stated range.
By their numbers in this assay, from the lowest: compounds 3, 2 and 1 (each within the scatter of the next, the first and the last beyond it).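

In this assay, among these compounds, the step of a 1.4-fold lower number from compound 2 to compound 3 (0.15 log units; within the scatter) gives the first reading of any change at this position, with methoxy in place of hydrogen on an aromatic carbon of the six-membered aromatic ring of carbon only. It shows that putting methoxy on this carbon leaves the number within the scatter of the one for hydrogen, so the two compounds cannot be placed in an order, and this single step gives no sign that the position matters for growth inhibition in these cells. Nothing in the available evidence bears on this result.

The compounds shown leave open whether another group on this same aromatic carbon, such as an amine, a carboxylic acid or a longer alkoxy chain, would move the number beyond the scatter. They also leave open whether methoxy would give the same small step on another carbon of this ring.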